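This account rests on a few compounds, and the source may have more. Where it says the series, first, only, none or still open, it means among the compounds named here.

Measured so far:
Compound 1 `CCC(=O)c1cc(O)c(O)c(O)c1` — 8100 nM
Compound 2 `O=C(O)/C=C/c1cc(O)c(O)c(O)c1` — 7200 nM

In a functional assay for inhibition, read by spectrophotometry, with a stated time of 15 min (a lower number here means a stronger inhibitor, a higher number a weaker inhibitor), compound 2 gives 7200 nM, and compound 1 gives 8100 nM; the two numbers lie within the scatter of each other, so neither stands apart. Compound 3 `CCOC(=O)/C=C/c1cc(O)c(O)c(O)c1` has not yet been measured. It differs from compound 2 in one place: ethyl in place of hydrogen on an oxygen next to a carbonyl group. Going by the values given here, no measured pair shows this change, so the step in this assay can only be expected to be small, in no particular direction, and not beyond the scatter. Compound 3 is estimated at 7000 nM, between 2500 nM and 20000 nM, which means an expected step of a 1.0-fold lower number from compound 2 to compound 3 (0.01 log units; within the scatter).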

Compound 3, half-maximal inhibitory concentration: 9000 nM
Estimate against measurement, compound 3: 1.3-fold (0.11 log units) below; measured number inside the range.
By their numbers in this assay, from the lowest: compounds 2, 1 and 3 (each within the scatter of the next).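

In this assay, ethyl in place of hydrogen on an oxygen next to a carbonyl group gives a 1.3-fold higher number from compound 2 to compound 3 (0.10 log units; within the scatter), so the carboxy and ethoxycarbonyl forms cannot be told apart here. A free carboxy group is therefore not required for a number of this size on this core. Nothing measured on these compounds accounts for this result. As far as these compounds go, whether a longer chain or a ring on this oxygen would read the same remains open. So does the outcome of an amide in place of the ester.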